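This account rests on a few compounds, and the source may have more. Where it says the series, first, only, none or still open, it means among the compounds named here.

Compounds measured in an assay for binding affinity to dual specificity mitogen-activated protein kinase kinase 4 (Homo sapiens), read by KINOMEscan, tested at 100 nM; a higher number here means a weaker effect of the compound at the concentration tested, a lower number a stronger effect:
compound 1, `CCCS(=O)(=O)Nc1ccc(F)c(C(=O)c2n[nH]c3ncc(-c4ccccc4Cl)cc23)c1F`: 9.3%
compound 2, `CCCS(=O)(=O)Nc1ccc(F)c(C(=O)c2n[nH]c3ncc(-c4cccc(Cl)c4)cc23)c1F`: 40%
compound 3, `CCCS(=O)(=O)Nc1ccc(F)c(C(=O)c2n[nH]c3ncc(-c4cccc(F)c4)cc23)c1F`: 8.2%

Compound 3 gives the lowest of the three numbers in this assay; compound 1 lies nearest, a number 1.1 percentage points lower from compound 1 to compound 3 (within the scatter), and compound 2 furthest, a number 31.8 percentage points lower from compound 2 to compound 3 (beyond the scatter). Compound 4, `CCCS(=O)(=O)Nc1ccc(F)c(C(=O)c2n[nH]c3ncc(-c4cccc(C)c4)cc23)c1F`, differs from compound 3 by methyl in place of fluoro on an aromatic carbon. The step that bears on it is the one at the same position, a number 31.8 percentage points lower from compound 2 to compound 3 (beyond the scatter), which was large; the step of a number 30.7 percentage points higher from compound 1 to compound 2 (beyond the scatter) concerns the position of the group, not its identity. Within the data shown here, no measured step exchanges fluoro for methyl, so the direction rests on the one exchange seen there, and a rise in this assay is expected: a number 16.8 percentage points higher from compound 3 to compound 4 (beyond the scatter). Compound 4 is estimated at 25%, within 5% to 55%.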

Compound 4, a percentage reported as activity, at one concentration (the size of the read-out at that concentration, not a potency): 15%
Compound 4: the middle estimate sits 10 percentage points above what was measured; measured number inside the range.
By their numbers in this assay, from the lowest: compounds 3, 1 and 4 (each within the scatter of the next); then compound 2.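

In this assay, methyl and fluoro at this place cannot be told apart, a number 6.8 percentage points higher from compound 3 to compound 4 (within the scatter), while chloro stands apart from methyl, a number 25 percentage points lower from compound 2 to compound 4 (beyond the scatter), so the earlier rise seen with chloro does not extend to methyl. The 3-methylphenyl and 2-chlorophenyl groups also cannot be told apart, a number 5.7 percentage points higher from compound 1 to compound 4 (within the scatter). Nothing measured here accounts for chloro alone standing apart. On these data alone, whether a methoxy group, an amine or a nitrile at this place would read with fluoro and methyl or with chloro stays open. So does how 2-fluorophenyl or 2-methylphenyl would read.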